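This account rests on a few compounds, and the source may have more. Where it says the series, first, only, none or still open, it means among the compounds named here.

Three coumarin-bearing compounds were examined in an ADME assay on HEK293 cells (Homo sapiens) for cytotoxicity, read by MTT assay, with a stated time of 48 h; a lower number here means a stronger inhibitor, a higher number a weaker inhibitor. Compound 1 `Cc1ccc2oc(=O)cc(Cn3cc(Cn4c(=O)n(Cc5cn(Cc6cc(=O)oc7ccc(C)cc67)nn5)c5ccccc54)nn3)c2c1` gives 3580000 nM there, while compound 2 `O=c1cc(Cn2cc(Cn3c(=O)n(Cc4cn(Cc5cc(=O)oc6ccc(Cl)cc56)nn4)c4ccccc43)nn2)c2cc(Cl)ccc2o1` gives "not determined" (no result reported) in this assay. Compound 3 `COc1ccc2oc(=O)cc(Cn3cc(Cn4cnc5c4c(=O)n(C)c(=O)n5C)nn3)c2c1` gives 1380000 nM in this assay, the lower of the two numbers, with compound 1 lying beyond the usual scatter above it.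

Compound 4 `Cc1ccc2oc(=O)cc(Cn3cc(Cn4cnc5c4c(=O)n(C)c(=O)n5C)nn3)c2c1` is compound 3 with methyl in place of methoxy on an aromatic carbon. Among the measured compounds shown here, no comparable step between measured compounds exists, so the size of this step is open; compound 1, which also carries a methyl on its coumarin, sits at 3580000 nM, and a modest move toward a higher number, not beyond the scatter, seems plausible. Compound 4 is therefore expected to give about 1800000 nM in this assay, between 700000 nM and 4500000 nM. The step of a 1.3-fold higher number from compound 3 to compound 4 (0.12 log units; within the scatter) is estimated to stay within the scatter.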

Compound 4, half-maximal inhibitory concentration: 1110000 nM
Compound 4: the middle estimate sits 1.6-fold (0.21 log units) above what was measured, and the stated range covers the measured number.
By their numbers in this assay, from the lowest: compounds 4 and 3 (each within the scatter of the next); then compound 1.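

Methyl in place of methoxy on this aromatic carbon, meta to a fused ring and para to a fused ring, gives a 1.2-fold lower number from compound 3 to compound 4 (0.09 log units; within the scatter) in this assay on the shared core, the first step here that changes one place only. Among the compounds shown here, on this evidence, the two groups cannot be told apart at this position, something the earlier compounds could not show. Nothing at hand speaks to why they read alike.
As far as these compounds go, how an amine, a carboxylic acid or a longer chain on this same carbon would read remains open. So does whether methyl and methoxy would also read alike on the core of compound 1.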